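The compounds below may be only part of what the source reports. "The series", "measured", "known", "first", "only" and "open" are said of these compounds alone.

Compound 3 `COc1cc(/C=C/C(=O)Nc2ccccc2)ccc1OCCCCCCN(C)C` reads 1.69 in a physicochemical assay for lipophilicity, using the shake flask method, measured as octanol-water partition, at pH 7.4; a lower number here means a more polar compound, a higher number a more lipophilic compound; compound 2 `COc1cc(/C=C/C(=O)Nc2ccccc2)ccc1OCCCCCN(C)C` reads 1.61 and compound 1 `COc1cc(/C=C/C(=O)Nc2ccccc2)ccc1OCCCN(C)C` reads 1.55. The steps of a number 0.08 log units higher from compound 2 to compound 3 (within the scatter) and a number 0.14 log units higher from compound 1 to compound 3 (within the scatter) both stay inside the scatter, as does a number 0.06 log units higher from compound 1 to compound 2 (within the scatter). Compound 4 `CCN(CC)CCCCCCCCOc1ccc(/C=C/C(=O)Nc2ccccc2)cc1OC` differs from compound 3 in one place: 2-(diethylamino)ethyl in place of dimethylamino on a saturated chain carbon, six bonds along the chain from an oxygen on an aromatic ring. The three measured steps, each a lengthening of the same saturated chain, moved this assay only slightly, so a lengthening combined with the change from dimethylamino to diethylamino is expected to lift the value modestly, with the step of a number 0.31 log units higher from compound 3 to compound 4 (beyond the scatter) expected from compound 3 to compound 4. Compound 4 is therefore estimated at 2, between 1.7 and 2.4.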

Compound 4, partition coefficient: 1.75
For compound 4 the middle estimate is 0.25 log units above the measured one, within the range that was stated.
By their numbers in this assay, from the lowest: compounds 1, 2, 3 and 4 (each within the scatter of the next).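

In this assay, 2-(diethylamino)ethyl in place of dimethylamino, six bonds along the chain from an oxygen on an aromatic ring, gives a number 0.06 log units higher from compound 3 to compound 4 (within the scatter) and so does not separate the two compounds. The wider comparisons, a number 0.14 log units higher from compound 2 to compound 4 (within the scatter) and a number 0.20 log units higher from compound 1 to compound 4 (within the scatter), show that this combined change also leaves compound 4 within the scatter of the shorter dimethylamino compounds. No supporting information bears on this result.

The compounds shown leave open how a piperidine or morpholine in place of the diethylamino group, or a carboxylic acid in place of the amine, would read in this assay. They also leave open how diethylamino would read on an unchanged chain.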